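This account rests on a few compounds, and the source may have more. Where it says the series, first, only, none or still open, it means among the compounds named here.

In an assay on isolated protein for inhibition of Aromatase (Homo sapiens), read by fluorescence and colorimetric assay, with a stated time of 30 min (a higher number here means a weaker inhibitor, a lower number a stronger inhibitor), compound 3 `CCCCCCc1cn(C(c2ccccc2)c2ccccc2)nn1` gives 14800 nM, the highest of the three numbers shown. Compound 2 `COc1ccc(OCc2cn(C(c3ccc(C#N)cc3)c3ccc(C#N)cc3)nn2)cc1` gives 12200 nM, which lies within the scatter of compound 3, while compound 1 `N#Cc1ccc(OCc2cn(C(c3ccc(C#N)cc3)c3ccc(C#N)cc3)nn2)cc1` gives 4640 nM, a lower number beyond the scatter. Among the measured compounds shown here, the only measured step, a 2.6-fold higher number from compound 1 to compound 2 (0.42 log units; beyond the scatter), concerns a change on an aromatic carbon and does not bear on the change at hand. Compound 4 `Cc1ccc(OCc2cn(C(c3ccccc3)c3ccccc3)nn2)cc1` differs from compound 3 by 4-methylphenoxy in place of pentyl on a saturated chain carbon bound to an aromatic carbon. For the measured compounds named here, compounds 1 and 2 differ from compound 4 in more than one place, so no clean step guides the estimate, and the expectation is uncertain. In this assay compound 4 is expected to give 10000 nM, between 4000 nM and 25000 nM. That estimate means a 1.5-fold lower number from compound 3 to compound 4 (0.17 log units; within the scatter).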

Compound 4, half-maximal inhibitory concentration: 26800 nM
Compound 4: the middle estimate sits 2.7-fold (0.43 log units) below what was measured, outside the stated range (above it).
By their numbers in this assay, from the lowest: compound 1; then compounds 2, 3 and 4 (each within the scatter of the next, the first and the last beyond it).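

In this assay, among the compounds shown here, the swap of pentyl for 4-methylphenoxy on a saturated chain carbon bound to an aromatic carbon gives a 1.8-fold higher number from compound 3 to compound 4 (0.26 log units; within the scatter) and is the first reading at this position. Here a chain and a group carrying a six-membered aromatic ring and an oxygen cannot be told apart. Nothing at hand gives a reason for this result. The compounds shown leave open whether an amine or a carboxylic acid at this place would separate from compound 3. They also leave open whether a longer chain would do so.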